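The compounds below may be only part of what the source reports. "The series", "measured", "known", "first", "only" and "open" are said of these compounds alone.

Two analogues of a shared core have been measured in a functional assay on MEF cells (Mus musculus) for antiproliferative activity, read by luminescence, with a stated time of 16 h; a lower number here means that less compound is needed, a higher number that more compound is needed for the effect. Compound 1 `O=C(Nc1ccc(S(=O)(=O)N2CCC(F)CC2)cc1)c1ccc([N+](=O)[O-])o1` gives 17500 nM in this assay, and compound 2 `CC1(C)CCN(S(=O)(=O)c2ccc(NC(=O)c3ccc([N+](=O)[O-])o3)cc2)CC1` gives 3000 nM. Among the measured compounds shown here, the single step between them, a 5.8-fold lower number from compound 1 to compound 2 (0.77 log units; beyond the scatter), came from putting 4,4-dimethylpiperidin-1-yl in place of 4-fluoropiperidin-1-yl on the sulfonyl sulfur. For the measured compounds named here, on these two numbers compound 2 stands lowest, with compound 1 as its only neighbour at a higher number. Compound 3 `CC(C)(C)C1CCN(S(=O)(=O)c2ccc(NC(=O)c3ccc([N+](=O)[O-])o3)cc2)CC1` is the next case: 4-(tert-butyl)piperidin-1-yl in place of 4,4-dimethylpiperidin-1-yl on a sulfonyl sulfur. Going by the values given here, only the step from compound 1 to compound 2 bears on it, as that step also changed the group on the sulfonyl sulfur, and it was modest in size. The present change keeps the same ring and alters only what sits on it, so no step beyond the scatter is expected in this assay, with a small further lowering as the most that seems likely. Compound 3 is therefore expected to give 2200 nM in this assay, within a range of 800 nM to 6000 nM. That amounts to an expected step of a 1.4-fold lower number from compound 2 to compound 3 (0.13 log units; within the scatter).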

Compound 3, half-maximal effective concentration: 1400 nM
The estimate for compound 3 lay 1.6-fold (0.20 log units) above the measured number; the range from low to high includes it.
By their numbers in this assay, from the lowest: compound 3; then compound 2; then compound 1.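

In this assay, the swap of 4,4-dimethylpiperidin-1-yl for 4-(tert-butyl)piperidin-1-yl on the sulfonyl sulfur, with 10 heavy atoms entering for 8 and neither group carrying a hydrogen-bond donor or acceptor, gives a 2.1-fold lower number from compound 2 to compound 3 (0.33 log units; beyond the scatter). This shows that the read-out at this position responds to a change between two carbon substituents on the same piperidine ring, and not only to the removal of fluoro. Over the whole series, tert-butyl in place of fluoro on a saturated ring carbon gives a 13-fold lower number from compound 1 to compound 3 (1.10 log units; beyond the scatter), a large step that places the three compounds in a single order, with none going against it, although nothing available accounts for that order.

The compounds shown leave open whether the number keeps falling with still more carbon on the ring, as with a phenyl or cyclohexyl group in the place of tert-butyl, or whether it turns back. They also do not tell how a hydroxyl group, an amine or a carboxylic acid at that ring carbon would behave, so the order holds only for fluoro, the two methyl groups and tert-butyl.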